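A few compounds are considered here, and "the series" means these few. Any claim that something is new, unique, unknown or untested is made for them only; others in the source may bear on it.

Compound 1, `CCCOc1nc2c(c(=O)n(C)c(=O)n2C)n1CCCN1CCN(c2cccc(Cl)c2)CC1`, gives 267 nM in an assay on cell membranes (strain Wistar) for displacement of a labelled ligand from 5-hydroxytryptamine receptor 7 (Rattus norvegicus); a higher number here means a weaker inhibitor, a lower number a stronger inhibitor.
Compound 2, `CCOc1nc2c(c(=O)n(C)c(=O)n2C)n1CCCCN1CCc2ccccc2C1`, gives 83 nM in this assay.

Among the compounds with values here, of the two measured compounds, compound 2 stands at the lower number in this assay; compound 1, its only neighbour, sits higher by a gap that goes beyond the usual scatter. The two compounds differ in more than one place, so what drives that gap cannot be told from these values alone.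

Compound 3, `CCCOc1nc2c(c(=O)n(C)c(=O)n2C)n1CCCCN1CCc2ccccc2C1`, differs from compound 2 only by methyl in place of hydrogen on a saturated chain carbon, two bonds along the chain from an oxygen on an aromatic ring. Within the data shown here, no pair of measured compounds shows this change on its own, so its direction is not known from the data. A change of this kind, a single added carbon on the chain, is expected to move the number only modestly, if at all, with no step beyond the scatter anticipated in either direction.

On that basis compound 3 is expected to give about 85 nM in this assay, with a range from 30 nM to 250 nM. The step from compound 2 to compound 3 that this estimate implies is a 1.0-fold higher number from compound 2 to compound 3 (0.01 log units; within the scatter).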

Compound 3, inhibition constant: 57 nM
The estimate for compound 3 lay 1.5-fold (0.17 log units) above the measured number, within the range that was stated.
By their numbers in this assay, from the lowest: compounds 3 and 2 (each within the scatter of the next); then compound 1.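

In this assay, within the data shown here, the change from ethoxy to propoxy, methyl in place of hydrogen on a saturated chain carbon, two bonds along the chain from an oxygen on an aromatic ring, gives a 1.5-fold lower number from compound 2 to compound 3 (0.16 log units; within the scatter) and so provides the first reading of this change on its own. At this position, the added carbon therefore leaves the number within the scatter, and the two chains cannot be told apart by this single pair. No measured evidence bears on why this is so.

The compounds shown leave open whether a longer chain such as butoxy, or a branched one such as isopropoxy, would also stay within the scatter. Compound 1 differs from compound 3 in more than one place, so what separates them remains unresolved.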